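This account rests on a few compounds, and the source may have more. Where it says the series, first, only, none or still open, it means among the compounds named here.

Within the data shown here, in a functional assay on ECV-304 cells (Homo sapiens), read by MTT assay, with stated times of 24 h and 12 h (on this read-out lower numbers stand for an effect already at smaller amounts and higher numbers for an effect only at larger amounts of compound), compound 1 `CNC(=N)NC(=O)c1nc(C)c(C)nc1C` gives 97000 nM and compound 2 `Cc1nc(C)c(C(=O)NC(=N)NCc2cccc(Cl)c2)nc1C` gives 59000 nM, so compound 2 stands within the scatter of the only other measured value. Compound 3 `Cc1nc(C)c(C(=O)NC(=N)NCc2ccc(Cl)c(Cl)c2)nc1C` differs from compound 2 by chloro in place of hydrogen on an aromatic carbon. Among the measured compounds shown here, the only measured step bearing on this, a 1.6-fold lower number from compound 1 to compound 2 (0.22 log units; within the scatter), lies within the scatter, so no step beyond the scatter is expected in this assay, with any drift expected toward a lower number. The estimated step is a 1.3-fold lower number from compound 2 to compound 3 (0.12 log units; within the scatter). For compound 3 the expected value is 45000 nM, with an estimated range of 18000 nM to 100000 nM.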

Compound 3, half-maximal effective concentration: 94000 nM
Compound 3: middle estimate off by 2.1-fold (0.32 log units), on the low side; low and high end bracket the measured number.
By their numbers in this assay, from the lowest: compounds 2, 3 and 1 (each within the scatter of the next).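

In this assay the added chloro group, ortho to a chloro group and para to a large group, gives a 1.6-fold higher number from compound 2 to compound 3 (0.20 log units; within the scatter) and so shows no effect that can be separated from the scatter at this position. The change from hydrogen on the chain carbon to the full 3,4-dichlorophenyl group gives a 1.0-fold lower number from compound 1 to compound 3 (0.01 log units; within the scatter) and likewise stays within the scatter. No measurement at hand offers an explanation for these results. Going by these compounds, whether methoxy or an amine at this place would move the number beyond the scatter stays open, as does the effect of a longer chain carrying the phenyl ring.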